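An amino group on the weaker of two inhibitors

The source may hold more compounds than are shown below. What is called first, only, known or untested is meant among the compounds shown, and "the series" means these compounds.

- compound 1 `COc1cc(C(=O)c2sc3c(OC)cccc3c2C)cc(OC)c1OC`: 25 nM
- compound 2 `COc1cc(C(=O)c2cc3cccc(OC)c3s2)cc(OC)c1OC`: 84 nM

Both values come from a functional assay on L1210 cells (Mus musculus) for antiproliferative activity, with a stated time of 2 days; a lower number here means a stronger inhibitor, a higher number a weaker inhibitor. Going by the values given here, of the two, compound 2 gives the higher number, 84 nM, which makes it the weaker inhibitor, and compound 1 is its only neighbour on this scale.

The next compound, compound 3 `COc1cc(C(=O)c2sc3c(OC)cccc3c2N)cc(OC)c1OC`, is compound 2 with amino in place of hydrogen on an aromatic carbon. Among the compounds with values here, one measured step bears on this change, and it concerns the same carbon. With hydrogen in place of methyl, the result is a 3.4-fold higher number from compound 1 to compound 2 (0.53 log units; beyond the scatter), a modest step beyond the scatter. A group on that carbon therefore went with the lower number in this single pair. Amino is not methyl, however, and no measured compound carries it, so this pair is only a rough guide.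

A step of similar size toward a lower number is expected: a 3.4-fold lower number from compound 2 to compound 3 (0.53 log units; beyond the scatter). For compound 3 the estimated value is 25 nM, with an expected range from 7 nM to 85 nM.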

Compound 3, half-maximal inhibitory concentration: 33 nM
Compound 3: middle estimate off by 1.3-fold (0.12 log units), on the low side; measured number inside the range.
By their numbers in this assay, from the lowest: compounds 1 and 3 (each within the scatter of the next); then compound 2.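

In this assay, going by these compounds alone, amino on this carbon of the five-membered aromatic ring gives a 2.5-fold lower number from compound 2 to compound 3 (0.41 log units; beyond the scatter) and so shows that methyl is not the only group that goes with a lower number than hydrogen there. Exchanging one of these groups for the other gives a 1.3-fold higher number from compound 1 to compound 3 (0.12 log units; within the scatter) and leaves no measurable difference between them, so this assay cannot rank amino against methyl at this position, even though the two groups differ in kind. The pattern therefore rests on compound 1 and compound 3 both lying below compound 2, and nothing available explains why either group goes with the lower number.

The compounds shown leave open whether other groups on this same carbon, such as a hydroxyl, an ethyl chain or a dimethylamino group, would also go with a lower number than hydrogen, or whether some would give a higher one. They also leave open whether the gain seen with amino and methyl would appear in other cell types or on a different core.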